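Lengthening the ester chain of compound 1

A few compounds are considered here, and "the series" means these few. Any claim that something is new, unique, unknown or untested is made for them only; others in the source may bear on it.

In a functional assay on U-373MG ATCC cells (Homo sapiens) for inhibition, read by MTT assay, with a stated time of 72 h (a higher number here means a weaker inhibitor of growth, a lower number a stronger inhibitor of growth), compound 1 (`CCOC(=O)/C=C/C1=CC[C@H]2C(C)(C)CCC[C@]2(C)[C@H]1C=O`) gives 37000 nM and stands level with its two measured relatives, since all three numbers lie within the scatter of one another. Compound 2 (`COC(=O)/C=C/C=C/C1=CC[C@H]2C(C)(C)CCC[C@]2(C)[C@H]1C=O`) gives 27000 nM in the same test, and compound 3 (`CC1(C)CCC[C@]2(C)[C@@H](C=O)C(/C=C/C#N)=CC[C@@H]12`) gives 36000 nM there. Compound 4 (`C#CCCCOC(=O)/C=C/C1=CC[C@H]2C(C)(C)CCC[C@]2(C)[C@H]1C=O`) keeps the shared core and the ester function of compound 1. Its change is propargyl in place of hydrogen on a saturated chain carbon, two bonds along the chain from an oxygen next to a carbonyl group so that ethyl becomes pent-4-yn-1-yl. For the measured compounds named here, no measured step alters this ester chain, so the data offer only indirect guidance. The nearest evidence comes from replacing the whole ethoxycarbonyl group, and both a 1.4-fold lower number from compound 1 to compound 2 (0.14 log units; within the scatter) and a 1.0-fold lower number from compound 1 to compound 3 (0.01 log units; within the scatter) stay small. On that basis no shift beyond the scatter is expected in this assay for the longer chain, although this remains an untested extrapolation. The estimated change is a 1.2-fold lower number from compound 1 to compound 4 (0.09 log units; within the scatter) and would be no real change. For compound 4 the expected value is 30000 nM with 13000 nM to 65000 nM as the estimated range.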

Compound 4, concentration for 50% growth inhibition: 35000 nM
Estimate against measurement, compound 4: 1.2-fold (0.07 log units) below, and the stated range covers the measured number.
By their numbers in this assay, from the lowest: compounds 2, 4, 3 and 1 (each within the scatter of the next).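

For the compounds shown here, the ester chain itself changes here for the first time: with pent-4-yn-1-yl in place of ethyl, the step is a 1.1-fold lower number from compound 1 to compound 4 (0.02 log units; within the scatter) in this assay, so this position accepts the added propargyl and its triple bond with no shift beyond the scatter. The two other new comparisons also stay small, at a 1.0-fold lower number from compound 3 to compound 4 (0.01 log units; within the scatter) and a 1.3-fold higher number from compound 2 to compound 4 (0.11 log units; within the scatter), which leaves compound 1, compound 2, compound 3 and compound 4 level with one another. Nothing among the data gives a reason for this flat result.

On these data alone, whether a plain pentyl chain without the triple bond would read the same remains open. So does whether a carboxylic acid or an amide in place of the ester would give a number outside this narrow band.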